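Piperazine amide variation on a dichlorinated oxindole-type series

The compounds below may be only part of what the source reports. "The series", "measured", "known", "first", "only" and "open" are said of these compounds alone.

Of the compounds shown here, two have been measured in an in vitro functional assay on CHO-CREluc cells for antagonist activity at growth hormone secretagogue receptor type 1 (Homo sapiens), read by a luciferase reporter, with a stated time of 4 h; on this read-out higher numbers stand for weaker inhibition and lower numbers for stronger inhibition. Compound 1 `CCN1CCN(CC(=O)NC2(c3ccc(Cl)c(Cl)c3)C(=O)Nc3cc(Cl)cc(Cl)c32)CC1=O` gives 2780 nM and is the higher of the two numbers. Compound 2 `CN1CCN(CC(=O)N[C@]2(c3ccc(Cl)cc3)C(=O)Nc3cc(Cl)c(Cl)cc32)CC1` gives 47 nM, a number well beyond the scatter below that of compound 1; the two compounds differ in more than one place, so their values are taken only as they stand.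

Compound 3 `C=CCN1CCN(CC(=O)NC2(c3ccc(Cl)c(Cl)c3)C(=O)Nc3cc(Cl)cc(Cl)c32)CC1` has not been measured. It differs from compound 1 in one place: 4-allylpiperazin-1-yl in place of 4-ethyl-3-oxopiperazin-1-yl on a saturated chain carbon bound to a carbonyl carbon. Among the measured compounds shown here, no pair of measured compounds differs in this change alone, so its size is not known from the series. The estimate for compound 3 is 600 nM, with a range from 150 nM to 2500 nM, placing it between the two measured values because compound 2 gives 47 nM. The expected step of a 4.6-fold lower number from compound 1 to compound 3 (0.67 log units; beyond the scatter) would be a decrease beyond the scatter, towards stronger inhibition, but with wide uncertainty.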

Compound 3, half-maximal inhibitory concentration: 38 nM
Compound 3: the middle estimate sits 16-fold (1.20 log units) above what was measured; measured number outside the range, below it.
By their numbers in this assay, from the lowest: compounds 3 and 2 (each within the scatter of the next); then compound 1.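

In this assay, among the compounds shown here, 4-allylpiperazin-1-yl in place of 4-ethyl-3-oxopiperazin-1-yl on a saturated chain carbon bound to a carbonyl carbon gives a 73-fold lower number from compound 1 to compound 3 (1.86 log units; beyond the scatter), the first single-place step, and it shows that the read-out is highly sensitive to the group at this place on the core of compound 1. The two groups match in ring type and heavy-atom count, but the entering group lacks the ring carbonyl and carries allyl instead of ethyl, so two features change together and the step cannot be assigned to either. No measurement on hand explains the size of this step.

Which feature carries the step remains open: 4-ethylpiperazin-1-yl or 4-allyl-3-oxopiperazin-1-yl at this place would separate the two. Also open, on these data alone, is whether the step holds on the core of compound 2.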